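From 3-methoxyphenyl to 3,5-dichlorophenyl: a step into the unknown

A few compounds are considered here, and "the series" means these few. Any claim that something is new, unique, unknown or untested is made for them only; others in the source may bear on it.

In a functional assay on MDA-MB-231 cells (Homo sapiens) for cytotoxicity, read by cell counting, with a stated time of 48 h (a higher number here means a weaker inhibitor, a lower number a stronger inhibitor), compound 1 (`Cc1ccc(-n2cc(COc3cccc4cnc(Nc5cccc(Cl)c5)nc34)nn2)c([N+](=O)[O-])c1`) reads > 25000 nM, which is a limit of the assay and not a number. Going by the values given here, compound 2 (`COc1cccc(-n2cc(COc3cccc4cnc(Nc5cccc(Cl)c5)nc34)nn2)c1`) gives 25000 nM, the only true number so far. Among the compounds with values here, the single measured step, a number no higher from compound 1 to compound 2 (the limit leaves the size open), has no readable size because of the limit of > 25000 nM in this assay, at which 1 of the 2 values shown sits. Compound 3 (`Clc1cccc(Nc2ncc3cccc(OCc4cn(-c5cc(Cl)cc(Cl)c5)nn4)c3n2)c1`) carries 3,5-dichlorophenyl in place of 3-methoxyphenyl on an aromatic nitrogen. Within the data shown here, with no sized step to guide it, the expected change in this assay, a 1.3-fold lower number from compound 2 to compound 3 (0.10 log units; within the scatter), stays within the scatter, in no set direction. The estimate for compound 3 is 20000 nM, within an expected range of 8000 nM to 40000 nM.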

Compound 3, half-maximal inhibitory concentration: 9000 nM
Compound 3: the middle estimate sits 2.2-fold (0.35 log units) above what was measured, within the range that was stated.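

In this assay, this position now shows a change of readable size: 3,5-dichlorophenyl and 3-methoxyphenyl have the same heavy-atom count, yet the swap gives a 2.8-fold lower number from compound 2 to compound 3 (0.44 log units; beyond the scatter). The comparison with 4-methyl-2-nitrophenyl gives an at least 2.7-fold lower number from compound 1 to compound 3 (0.44 log units; beyond the scatter) and sets only a minimum size, as the value for compound 1 is a limit: the limit of > 25000 nM in this assay, at which 1 of the 3 values shown sits.

Whether both chlorines are needed remains open, since a single chlorine on the phenyl ring is not among these compounds. On these data alone, how an amine or a carboxylic acid on that ring would read also remains unknown.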